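Fluoro substitution on the outer aromatic ring of compound 1

The source may hold more compounds than are shown below. What is called first, only, known or untested is meant among the compounds shown, and "the series" means these compounds.

Measured compounds:
compound 1 `N#CN1CC(OCc2ccc(-c3ccccc3)cc2)C1` gives 2.8 nM
compound 2 `N#CN1CC(OCc2ccc(-c3cccc(OCc4ccccc4)c3)cc2)C1` gives 1.4 nM
compound 3 `COc1cccc(-c2ccc(COC3CN(C#N)C3)cc2)c1OC` gives 0.88 nM

All three numbers come from an assay on isolated protein for inhibition of N-acylethanolamine-hydrolyzing acid amidase (Homo sapiens), read by fluorescence, with a stated time of 90 min; a higher number here means a weaker inhibitor, a lower number a stronger inhibitor. Compound 1 has the highest number of the three. Its nearest neighbour is compound 2, and that step, a 2.0-fold lower number from compound 1 to compound 2 (0.30 log units; within the scatter), is within the scatter. Compound 3 is furthest away; it differs from compound 1 in more than one place, so only the two values stand side by side, and the gap between them lies beyond the scatter.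

Compound 4 `N#CN1CC(OCc2ccc(-c3ccc(F)cc3)cc2)C1` has not been measured. It differs from compound 1 by fluoro in place of hydrogen on an aromatic carbon, on an aromatic carbon of a six-membered aromatic ring of carbon only, para to a large group; read one bond further out, phenyl becomes 4-fluorophenyl.

Among the compounds with values here, only one measured step bears on this change: the replacement of hydrogen by benzyloxy on an aromatic carbon of the same ring, a 2.0-fold lower number from compound 1 to compound 2 (0.30 log units; within the scatter), which was within the scatter. The fluoro group is a single heavy atom with no donors or acceptors, far smaller than benzyloxy. With a substituent of another kind on that ring giving no step beyond the scatter, no step beyond the scatter is expected here either. The step from compound 1 to compound 4 is therefore estimated as a 1.1-fold lower number from compound 1 to compound 4 (0.05 log units; within the scatter). Compound 4 is estimated at 2.5 nM, within a range of 1 nM to 6 nM.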

Compound 4, half-maximal inhibitory concentration: 0.68 nM
Beside the measured number, compound 4's estimate is 3.7-fold (0.57 log units) above it, and the stated range ends above it.
By their numbers in this assay, from the lowest: compounds 4, 3, 2 and 1 (each within the scatter of the next, the first and the last beyond it).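

In this assay, within the data shown here, fluoro in place of hydrogen on an aromatic carbon, para to a large group, gives a 4.1-fold lower number from compound 1 to compound 4 (0.61 log units; beyond the scatter) as the first single-place step in this set to lie beyond the scatter. Among these compounds, the only earlier single-place step, a 2.0-fold lower number from compound 1 to compound 2 (0.30 log units; within the scatter) with benzyloxy on the same outer ring, stayed within the scatter, so compound 2 gave no clear sign that this ring could move the number, whereas compound 4 shows that it can, and that one entering heavy atom is enough. No measurement among the data accounts for this step, which stands here as an observation only.

Going by these compounds, it remains open whether the step is specific to fluoro or would also appear with other small groups at this place, such as chloro, methyl or methoxy, and whether a charged group such as an amine or a carboxylic acid would be accepted there. Also open, on these data alone, is how fluoro would read at the other carbons of the outer ring, and whether the step would hold on a core carrying further substituents on that ring.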